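Nitro count on the benzyl ring and tolerance in cells

The source may report more compounds than this note shows. Statements on the series, on what has been measured and on what is new or still open speak of the compounds shown alone.

Measured compounds:
Compound 1 `O=c1[nH]c(SCc2cc([N+](=O)[O-])cc([N+](=O)[O-])c2)nc2ccccc12` gives > 64000 nM in this assay, a limit.
Compound 2 `O=c1[nH]c(SCc2ccccc2[N+](=O)[O-])nc2ccccc12` gives > 64000 nM, a limit.
Compound 3 `O=c1[nH]c(SCc2cccc([N+](=O)[O-])c2)nc2ccccc12` gives > 64000 nM, a limit.

In an ADME assay on MRC5 cells (Homo sapiens) for cytotoxicity, read by neutral red uptake (a higher number here means that more compound is tolerated, a lower number that less compound is tolerated), all three measured compounds return only a limit rather than a number. The step that the two limits leave unreadable from compound 3 to compound 1 is made by the change (nitro in place of hydrogen on an aromatic carbon); because both ends sit at a limit, its size cannot be read, as the limit of > 64000 nM in this assay, at which 3 of the 3 values shown sit, records. Compound 2 and compound 3 are built from the same atoms joined differently, and the difference between the two is not broken down here; what their two values show is that each lies at the limit.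

The unmeasured compound 4 `O=c1[nH]c(SCc2c([N+](=O)[O-])cccc2[N+](=O)[O-])nc2ccccc12` arises from compound 2 by nitro in place of hydrogen on an aromatic carbon. Within the data shown here, this is the same kind of change as the one from compound 3 to compound 1, though the surroundings differ: in compound 4 the entering nitro is ortho to a large group, whereas in compound 1 it is meta to a large group. The expectation rests on compound 2 at > 64000 nM and on the fact that the earlier step of this kind remained unreadable between two limits. Compound 4 is therefore expected to show a step of about a number no higher from compound 2 to compound 4 (the limit leaves the size open) from compound 2. For compound 4 in this assay the estimate is 64000 nM, between 30000 nM and 150000 nM, most likely reported again only as a limit.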

Compound 4, half-maximal cytotoxic concentration: > 64000 nM
Compound 4: only a limit was reported (the forecaster's own chance of this, stated with the estimate: 85%); the middle value sits exactly at the limit.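

In this assay compound 4 gives > 64000 nM, which is a limit. Compound 2 sits at a limit too, so no step from it to compound 4 can be read: the limit of > 64000 nM in this assay, at which 4 of the 4 values shown sit.

The compounds shown leave open what actual value any of them has in this assay, and whether a second nitro group changes that value at all.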